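From benzyloxy to phenethyl in compound 4

A few compounds are considered here, and "the series" means these few. Any claim that something is new, unique, unknown or untested is made for them only; others in the source may bear on it.

Measured in a functional assay on HT-1080 cells (Homo sapiens) for antiproliferative activity, read by MTT assay; a higher number here means a weaker inhibitor, a lower number a stronger inhibitor:
- compound 1 `Cc1cc(=O)c(O)c(Cc2ccc(F)cc2)o1`: > 50000 nM, a limit
- compound 2 `Cc1cc(=O)c(O)c(Cc2ccc(OCc3ccccc3)cc2)o1`: > 50000 nM, a limit
- compound 3 `Cc1cc(=O)c(O)c(C(c2ccc(OCc3ccccc3)cc2)c2oc(C)cc(=O)c2O)o1`: 1430 nM

Only compound 3 has a true number here, as the other two values are limits. A second unit of the shared core replaces a hydrogen atom in an at least 34-fold lower number from compound 2 to compound 3 (1.54 log units; beyond the scatter). Compound 4 `Cc1cc(=O)c(O)c(C(c2ccc(CCc3ccccc3)cc2)c2oc(C)cc(=O)c2O)o1` keeps that second unit and changes one group: phenethyl in place of benzyloxy on an aromatic carbon. Going by the values given here, the only measured step at this place is a step that the two limits leave unreadable from compound 1 to compound 2, and it gives no size. Both groups hold one six-membered aromatic ring of carbon only, so, starting from compound 3 at 1430 nM, no change beyond the scatter is expected. The expected step is a 1.1-fold lower number from compound 3 to compound 4 (0.04 log units; within the scatter). For compound 4 the estimate is 1300 nM, with an expected range from 450 nM to 4000 nM.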

Compound 4, half-maximal inhibitory concentration: > 50000 nM
Compound 4 was reported as a limit; the forecaster's own chance of this, stated with the estimate: 5%; middle value at least 38-fold (1.58 log units) away from the limit.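

With the second unit of the shared core in place, this position proves sensitive: in this assay, phenethyl in place of benzyloxy gives an at least 34-fold higher number from compound 3 to compound 4 (1.54 log units; beyond the scatter). Both groups hold one six-membered aromatic ring of carbon only, so what separates this pair is a carbon where benzyloxy has its oxygen. Compound 4 gives only a limit, so the full size of this step cannot be read: the limit of > 50000 nM in this assay, at which 3 of the 4 values shown sit.

From the compounds shown here alone, whether an amine at this place, or a longer chain that keeps the oxygen, would retain the activity of compound 3 remains open.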